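This account rests on a few compounds, and the source may have more. Where it says the series, first, only, none or still open, it means among the compounds named here.

Measured compounds:
- compound 1 `COc1cc(C(=O)O)ccc1OCCCCOc1ccc(C(=O)C(C)C)c(O)c1C`: 25.6%
- compound 2 `CCC(=O)c1ccc(OCCCCOc2ccc(C(=O)O)cc2C)c(C)c1O`: 22.7%
- compound 3 `COc1cc(C(=O)O)ccc1OCCCCOc1ccc(C(=O)CC(C)(C)C)c(O)c1C`: 109%

In an assay on HEK293 cells for positive allosteric modulation of metabotropic glutamate receptor 3 (Rattus norvegicus), read by thallium flux, with a stated time of 2.5 min (on this read-out higher numbers stand for larger maximal responses and lower numbers for smaller maximal responses), compound 3 stands highest of the three numbers; the nearest is compound 1, which gives 25.6%, and compound 2 gives 22.7%, both well beyond the scatter below compound 3.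

Compound 4 `CCC(=O)c1ccc(OCCCCOc2ccc(C(=O)O)cc2OC)c(C)c1O` differs from compound 3 by methyl in place of tert-butyl on a saturated chain carbon bound to a carbonyl carbon. Going by the values given here, the only measured step that bears on this point of the series is a number 83.4 percentage points higher from compound 1 to compound 3 (beyond the scatter), a large gain on going to the larger group on the carbonyl carbon. Compound 4 moves the other way, to a group smaller even than the isopropyl of compound 1. Compound 2 carries the same propanoyl group but a different substituent on the other ring, so its value of 22.7% is only a hint, not a measured step. A large drop is therefore expected for compound 4, of the order of a number 84 percentage points lower from compound 3 to compound 4 (beyond the scatter). The expected maximal response for compound 4 in this assay is 25%, in the range 10% to 50%.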

Compound 4, largest response reached (reported as percent of maximum), in percent of the reference or control that the assay uses: 25.9%
For compound 4 the middle estimate is 0.9 percentage points below the measured one; low and high end bracket the measured number.
By their numbers in this assay, from the lowest: compounds 2, 1 and 4 (each within the scatter of the next); then compound 3.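

In this assay, methyl in place of tert-butyl on a saturated chain carbon bound to a carbonyl carbon gives a number 83.1 percentage points lower from compound 3 to compound 4 (beyond the scatter), so among the compounds shown the high response of compound 3 goes with the tert-butyl at this place. Hydrogen in place of methyl at the same place gives a number 0.3 percentage points higher from compound 1 to compound 4 (within the scatter), so the isopropyl and ethyl forms stand level, and the response does not fall step by step with group size across these compounds. Methoxy in place of methyl on an aromatic carbon gives a number 3.2 percentage points higher from compound 2 to compound 4 (within the scatter), so with the propanoyl group this change shows no effect.

Open, going by these compounds, is whether a cyclohexyl group or a longer chain in place of tert-butyl keeps the response, and whether methyl in place of methoxy on the aromatic carbon is equally silent with the tert-butyl present. Nothing at hand accounts for the size of the step at the carbonyl side chain.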